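Notes on a phenyl exchange in the series

The compounds below may be only part of what the source reports. "The series", "measured", "known", "first", "only" and "open" are said of these compounds alone.

- compound 1 `O=[N+]([O-])c1ccc(-c2ccc(O[C@H]3O[C@H](CO)[C@@H](O)[C@H](O)[C@@H]3O)c(Cl)c2)cc1` gives 2.3
- compound 2 `N#Cc1cccc(-c2ccc(O[C@H]3O[C@H](CO)[C@@H](O)[C@H](O)[C@@H]3O)c(Cl)c2)c1` gives 2.1

For the measured compounds named here, compound 2 stands level with the only other measured value in a physicochemical assay for lipophilicity, read by LC-MS, measured as octanol-water partition, with a stated time of 2 h, at pH 7.4, tested at 1 uM (a higher number here means a more lipophilic compound, a lower number a more polar compound), and so has no clear rank. Compound 3 `CC(=O)c1ccc(-c2ccc(O[C@H]3O[C@H](CO)[C@@H](O)[C@H](O)[C@@H]3O)c(Cl)c2)cc1` brings 4-acetylphenyl in place of 3-cyanophenyl on an aromatic carbon as its change from compound 2. Going by the values given here, the only measured step bearing on this exchange is a number 0.20 log units lower from compound 1 to compound 2 (within the scatter) between two substituted phenyl groups. No measured value yet covers the 4-acetylphenyl group. The expected step is a number 0.10 log units higher from compound 2 to compound 3 (within the scatter) and none beyond the scatter is expected. Compound 3 is estimated at 2.2 with an expected range from 1.8 to 2.6 in this measurement.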

Compound 3, distribution coefficient: 2.1
The estimate for compound 3 lay 0.10 log units above the measured number; the measured number falls inside the stated range.
By their numbers in this assay, from the lowest: compounds 2, 3 and 1 (each within the scatter of the next).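

In this assay the exchange at this place, on an aromatic carbon para to a large group, gives no change at the digits printed from compound 2 to compound 3 (within the scatter), and acetyl in place of nitro gives a number 0.20 log units lower from compound 1 to compound 3 (within the scatter). Compounds 1, 2 and 3 therefore show that three different substituted phenyl groups, with the substituent at either of two ring positions, remain within the scatter of one another. No measurement shown here offers an explanation for these readings.

Still open, as far as these compounds go, is whether a phenyl group bearing an amine or a carboxylic acid would give a step beyond the scatter. From the compounds shown here alone, a longer chain in place of the phenyl group is equally open.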